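Swapping fluoro for amino in compound 2

The source may report more compounds than this note shows. Statements on the series, on what has been measured and on what is new or still open speak of the compounds shown alone.

In a functional assay on MCF7 cells (Homo sapiens) for inhibition, with a stated time of 48 h, tested at 50 uM (a higher number here means more inhibition of growth at the concentration tested, a lower number less inhibition of growth), two compounds with a shared core have been tested so far. Compound 1 `COc1ccc(/C=C/[C@@](C)(/C=C/c2ccc(O)cc2)CCC=C(C)C)cc1` reaches 55% there, while compound 2 `CC(C)=CCC[C@](C)(/C=C/c1ccc(O)cc1)/C=C/c1ccc(F)cc1` reaches 28% and so holds the lower of the two numbers. Compound 3 `CC(C)=CCC[C@@](C)(/C=C/c1ccc(N)cc1)/C=C/c1ccc(O)cc1` has not yet been measured. It differs from compound 2 in one group, with amino in place of fluoro on an aromatic carbon, para to a large group (amino in place of fluoro on an aromatic carbon). Going by the values given here, the only measured step at this place is a number 27 percentage points lower from compound 1 to compound 2 (beyond the scatter) with fluoro in place of methoxy on an aromatic carbon. That step shows that the group here can move the number beyond the scatter, but it involves no amino, so it is weak evidence. Fluoro now leaves rather than enters, so an upward move of similar or smaller size is expected. The estimated move is a number 14 percentage points higher from compound 2 to compound 3 (beyond the scatter) in all. Compound 3 is expected at 42% on this reading, with a range from 18% to 68% around that estimate.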

Compound 3, percent growth inhibition at one concentration: 48%
Compound 3: the middle estimate sits 6 percentage points below what was measured; the measured number falls inside the stated range.
By their numbers in this assay, from the lowest: compound 2; then compounds 3 and 1 (each within the scatter of the next).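

Until now this position was known only from the change from methoxy to fluoro, which lowered the number. In this assay, the amino group gives a number 20 percentage points higher from compound 2 to compound 3 (beyond the scatter) and so shows that a group other than methoxy can also carry the number clear of the fluoro level at this place. Amino and methoxy cannot be told apart in this read-out, with a number 7 percentage points lower from compound 1 to compound 3 (within the scatter) as the step between them, so among these three compounds fluoro is the one group that stands apart, although nothing shown here explains why the number follows these groups.

Going by these compounds, what remains open is whether fluoro is the exception at this position or one of several groups that sit low, which a hydroxyl, a chlorine or a methyl group at the same place could begin to settle. An acetamide in place of the amino group would also test whether the free amine matters or whether a larger nitrogen-bearing group serves as well, and each of these readings would still come from a single concentration.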